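This account rests on a few compounds, and the source may have more. Where it says the series, first, only, none or still open, it means among the compounds named here.

Three compounds share a symmetric layout in which a central carbon, doubly bonded to nitrogen, carries two amide-type nitrogens and one further group, and they were tested in a functional assay on MCF7 cells (Homo sapiens) for cytotoxicity, read by MTT assay, with a stated time of 72 h; on this read-out lower numbers stand for stronger inhibition of growth and higher numbers for weaker inhibition of growth. Compound 1 (`CS/C(=N\C(=O)c1ccno1)NC(=O)c1ccno1`) carries a methylsulfanyl group on that carbon, and in this assay compound 1 gives 77800 nM. Compound 2 (`O=C(/N=C(/NC(=O)c1ccno1)[Se]Cc1ccccc1)c1ccno1`) carries instead the larger selenium-containing group, and in this assay compound 2 gives 7800 nM. The change from compound 2 to compound 1 is a group of 2 heavy atoms (1 carbon, 1 sulfur; no ring) in place of a group of 8 heavy atoms (7 carbon, 1 selenium; one six-membered aromatic ring of carbon only), on a carbon with a double bond to nitrogen and it made a step of a 10-fold higher number from compound 2 to compound 1 (1.00 log units; beyond the scatter).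

Compound 3 (`O=C(/N=C(/NC(=O)c1cc(-c2ccccc2)nc2ccccc12)[Se]Cc1ccccc1)c1cc(-c2ccccc2)nc2ccccc12`) keeps the selenium-containing group of compound 2 but has a different core on both ends; how the two cores differ is not broken down here. In this assay compound 3 gives 8460 nM, and the values of compound 2 and compound 3 lie within the scatter of each other.

Compound 4 (`CS/C(=N\C(=O)c1cc(-c2ccccc2)nc2ccccc12)NC(=O)c1cc(-c2ccccc2)nc2ccccc12`) is compound 3 with the change (a group of 2 heavy atoms (1 carbon, 1 sulfur; no ring) in place of a group of 8 heavy atoms (7 carbon, 1 selenium; one six-membered aromatic ring of carbon only), on a carbon with a double bond to nitrogen). The place is the same in both pairs, so this is the same change that was made from compound 2 to compound 1. For compound 4 a step of a 10-fold higher number from compound 3 to compound 4 (1.00 log units; beyond the scatter) is expected, because the same change gave a 10-fold higher number from compound 2 to compound 1 (1.00 log units; beyond the scatter) and the starting value of compound 3 is close to that of compound 2. The estimate for compound 4 in this assay is 85000 nM, expected to fall between 30000 nM and 250000 nM.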

Compound 4, concentration for 50% growth inhibition: 43100 nM
Compound 4: the middle estimate sits 2.0-fold (0.29 log units) above what was measured, and the stated range covers the measured number.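

In this assay, putting methylsulfanyl in place of the larger selenium-containing group, on a carbon with a double bond to nitrogen, again weakens growth inhibition, with a 5.1-fold higher number from compound 3 to compound 4 (0.71 log units; beyond the scatter). Set beside the earlier step on the other core, the change points the same way and the two sizes cannot be told apart: the same change on two cores in this assay, a 10-fold higher number (1.00 log units; beyond the scatter) from compound 2 to compound 1 and a 5.1-fold higher number (0.71 log units; beyond the scatter) from compound 3 to compound 4, 2.0-fold (0.29 log units) apart, within the scatter of two such steps This shows that, on these two cores, the effect of the change carried over from one to the other in direction and, within the scatter, in size; it does not show that the same would hold on any other core or in any other cell line, and with only two pairs it gives no reason for the step.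

The compounds shown leave open which part of the larger group matters, the selenium atom or the six-membered aromatic ring, and a pair with a benzylsulfanyl group or a methylselanyl group on the same carbon would help separate the two. Also open, on these data alone, is how the read-out would respond to a longer chain, such as ethylsulfanyl, or to an amine at that place.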